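The source may hold more compounds than are shown below. What is called first, only, known or untested is meant among the compounds shown, and "the series" means these compounds.

Measured in a functional assay on PC-3 cells (Homo sapiens) for inhibition, read by sulforhodamine B assay (on this read-out lower numbers stand for stronger inhibition of growth and higher numbers for weaker inhibition of growth), so far:
compound 1 `c1ccc(-c2ccc(-c3ccc(-c4nc5ccccc5[nH]4)cc3)cc2)cc1` gives 41200 nM
compound 2 `Fc1ccc(-c2ccc(-c3ccc(-c4nc5ccccc5[nH]4)cc3)cc2)cc1` gives 41200 nM
compound 3 `Clc1cccc(-c2ccc(-c3ccc(-c4nc5ccccc5[nH]4)cc3)cc2)c1` gives 33700 nM

Compound 1 is level with compound 2 at the digits shown, and compound 3 lies within the scatter of both. Compound 4 `Cc1ccc2[nH]c(-c3ccc(-c4ccc(-c5ccccc5)cc4)cc3)nc2c1` differs from compound 1 by methyl in place of hydrogen on an aromatic carbon of a six-membered aromatic ring of carbon only, part of a fused or bridged system of two rings. Among the measured compounds shown here, no measured compound carries a change at that place, so the guidance is indirect. Two substitutions elsewhere gave no change at the digits printed from compound 1 to compound 2 (within the scatter) and a 1.2-fold lower number from compound 1 to compound 3 (0.09 log units; within the scatter) and neither exceeds the scatter. In this assay no step beyond the scatter is therefore expected, and a 1.1-fold lower number from compound 1 to compound 4 (0.06 log units; within the scatter) is the estimated step. The estimate for compound 4 is 36000 nM with an expected range from 18000 nM to 70000 nM on repeated measurement.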

Compound 4, concentration for 50% growth inhibition: 100000 nM
Compound 4: middle estimate off by 2.8-fold (0.44 log units), on the low side; the measured number lies above the stated range.
By their numbers in this assay, from the lowest: compounds 3, 1 and 2 (each within the scatter of the next); then compound 4.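

Working notes: in this assay, methyl in place of hydrogen on an aromatic carbon of the six-membered carbon ring, part of the fused system of two rings, gives a 2.4-fold higher number from compound 1 to compound 4 (0.39 log units; beyond the scatter), the only step shown that lies beyond the scatter. Growth inhibition at this position therefore weakens with one added carbon, unlike the fluoro and chloro changes elsewhere in compound 2 and compound 3. Nothing at hand bears on the reason for this shift.

Still open, from the compounds shown here alone, is whether a hydroxyl, an amine or a carboxylic acid at this position would move the number in the same direction as methyl or the opposite one.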